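This account rests on a few compounds, and the source may have more. Where it says the series, first, only, none or still open, it means among the compounds named here.

Compound 1 `CC[C@H](C)[C@H](N)CN(C(=O)[C@@H]1C[C@H]1c1ccc(OC)cc1)c1ccc(-c2ccccc2)cc1` sits at the limit > 25000 nM in a functional assay for agonist activity at G protein-coupled receptor 88 (Homo sapiens), read by HTRF and cAMP accumulation (a higher number here means that more compound is needed for the effect, a lower number that less compound is needed), a limit and not a number. Compound 2 `CC[C@H](C)[C@H](N)CN(C(=O)[C@@H]1C[C@H]1c1ccc(C#N)cc1)c1ccc(-c2ccccc2)cc1` likewise sits at the limit > 25000 nM there. Compound 3 `CC[C@H](C)[C@H](N)CN(C(=O)[C@@H]1C[C@H]1c1c(F)cccc1F)c1ccc(-c2ccccc2)cc1` gives 11000 nM in this assay.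

Among the measured compounds shown here, compound 3 thus holds the only number of the three; the other two values are limits (the limit of > 25000 nM in this assay, at which 2 of the 3 values shown sit). Compound 4 `CC[C@H](C)[C@H](N)CN(C(=O)[C@@H]1C[C@H]1c1ccncc1)c1ccc(-c2ccccc2)cc1` arises from compound 3 by pyridin-4-yl in place of 2,6-difluorophenyl on a saturated ring carbon. For the measured compounds named here, two measured steps bear on the aryl on the saturated ring carbon: an at least 2.2-fold lower number from compound 1 to compound 3 (0.35 log units; beyond the scatter) and an at least 2.2-fold lower number from compound 2 to compound 3 (0.35 log units; beyond the scatter), each at least modest and both ending at the 2,6-difluorophenyl of compound 3. Leaving that group is expected to move the number back up, so compound 4 is estimated at 20000 nM (range 7000 nM to 60000 nM), a step of a 1.8-fold higher number from compound 3 to compound 4 (0.26 log units; within the scatter).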

Compound 4, half-maximal effective concentration: 1500 nM
Compound 4: the middle estimate sits 13-fold (1.12 log units) above what was measured, and the stated range ends above it.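

With pyridin-4-yl on the saturated ring carbon, this assay shows a 7.3-fold lower number from compound 3 to compound 4 (0.87 log units; beyond the scatter), so this position tolerates an aromatic ring with a hetero atom, and compound 4 outdoes every other aryl shown. Against the remaining two aryl groups the change gives an at least 16-fold lower number from compound 2 to compound 4 (1.22 log units; beyond the scatter) and an at least 16-fold lower number from compound 1 to compound 4 (1.22 log units; beyond the scatter). Both of these steps are lower bounds only, since their starting values are limits: the limit of > 25000 nM in this assay, at which 2 of the 4 values shown sit.

The compounds shown leave open whether the gain comes from the ring nitrogen or from the loss of the two fluorines. Plain phenyl and pyridin-3-yl at this position would separate these readings.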